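Chloro in place of hydrogen on the acetylphenol core

The source may hold more compounds than are shown below. What is called first, only, known or untested is meant among the compounds shown, and "the series" means these compounds.

Compound 1 `CCCc1cc(C(C)=O)c(O)cc1OCCCCC#N` gives 37% in an assay on isolated protein for binding affinity to leukotriene B4 receptor 1 (Homo sapiens), tested at 1 uM; on this read-out lower numbers stand for less inhibition and higher numbers for more inhibition at the one concentration tested (going by the name of the read-out); compound 2 `C=CCc1cc(C(C)=O)c(O)cc1OCCCCCC(=O)NO` gives 28%; compound 3 `CCCc1cc(C(C)=O)ccc1OCCCCC#N` gives 19%.

Compound 3 stands lowest of the three numbers, within the scatter of compound 2 and beyond it only against compound 1. Among the measured compounds shown here, the one measured step, a number 18 percentage points lower from compound 1 to compound 3 (beyond the scatter), also exchanged a substituent on an aromatic carbon, so it bears on the change to compound 4 `CCCc1cc(C(C)=O)c(Cl)cc1OCCCCC#N`: chloro in place of hydrogen on an aromatic carbon. For the measured compounds named here, no measured step involves chloro, so the direction is open; a step of modest size at most seems likely. The expected step is a number 5 percentage points higher from compound 3 to compound 4 (within the scatter). Compound 4 is estimated at 24%, within 5% to 48%.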

Compound 4, a percentage reported as inhibition, at one concentration (the size of the read-out at that concentration, not a potency): 13%
The estimate for compound 4 lay 11 percentage points above the measured number; the measured number falls inside the stated range.
By their numbers in this assay, from the lowest: compounds 4, 3, 2 and 1 (each within the scatter of the next, the first and the last beyond it).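

On the aromatic carbon ortho to an acetyl group, chloro and hydrogen cannot be told apart in this assay (a number 6 percentage points lower from compound 3 to compound 4 (within the scatter)). Against hydroxy the picture differs (a number 24 percentage points lower from compound 1 to compound 4 (beyond the scatter)), and the earlier step (a number 18 percentage points lower from compound 1 to compound 3 (beyond the scatter)) points the same way, so among these three groups only hydroxy stands apart at this carbon.

As far as these compounds go, whether an amine or a methoxy group at this carbon would match hydroxy stays open. No measurement shown here explains why hydroxy stands apart from chloro and hydrogen.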